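Methoxy for hydrogen on a pyrazoline aryl ring

The source may report more compounds than this note shows. Statements on the series, on what has been measured and on what is new or still open speak of the compounds shown alone.

Measured so far:
compound 1, `COc1ccc(C2=NN(C3=NC(=O)/C(=C4\C(=O)Nc5ccccc54)S3)C(c3ccc(OC)cc3)C2)cc1`, 85200 nM
compound 2, `O=C1N=C(N2N=C(c3ccccc3)CC2c2ccc(Cl)cc2)S/C1=C1/C(=O)Nc2ccccc21`, 270 nM

Two compounds carry numbers in a functional assay on cells (Cancer cell lines, Homo sapiens) for cytotoxicity, read by sulforhodamine B assay, with a stated time of 48 h; on this read-out higher numbers stand for weaker inhibition of growth and lower numbers for stronger inhibition of growth. Compound 1 gives 85200 nM, while compound 2 gives 270 nM. Compound 2 therefore holds the lowest of the two numbers, and its nearest neighbour, compound 1, stands far above it, a gap well beyond the scatter. Compound 1 and compound 2 differ in more than one place, so the two values only show how far apart the pair lies, not what any single change contributes.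

Compound 3, `COc1ccc(C2=NN(C3=NC(=O)/C(=C4\C(=O)Nc5ccccc54)S3)C(c3ccc(Cl)cc3)C2)cc1`, has not yet been measured in this assay. It differs from compound 2 in one place: methoxy in place of hydrogen on an aromatic carbon. Within the data shown here, no step for such a single change is available among the measured compounds, so the expected size rests on the wide gap between compound 1 and compound 2 alone. Since compound 1, which carries methoxy groups, sits at 85200 nM, a shift toward higher numbers is expected for compound 3, of uncertain size. The estimated step is a 7.4-fold higher number from compound 2 to compound 3 (0.87 log units; beyond the scatter). Compound 3 is expected to give about 2000 nM, with a plausible range from 300 nM to 20000 nM.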

Compound 3, concentration for 50% growth inhibition: 100000 nM
Compound 3: middle estimate off by 50-fold (1.70 log units), on the low side, and the stated range ends below it.
By their numbers in this assay, from the lowest: compound 2; then compounds 1 and 3 (each within the scatter of the next).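

In this assay, methoxy in place of hydrogen on an aromatic carbon, para to a large group, brings a 370-fold higher number from compound 2 to compound 3 (2.57 log units; beyond the scatter), so this one place, changed from phenyl to 4-methoxyphenyl, is enough on its own to carry a large step. With that methoxy kept, chloro in place of methoxy on an aromatic carbon at the other changed place brings a 1.2-fold higher number from compound 1 to compound 3 (0.07 log units; within the scatter), which lies within the scatter, so in this pair that second exchange does not separate the two compounds. Nothing available gives a reason for the size of the first step or for the absence of one in the second.

The compounds shown leave open how a hydroxy group, a fluorine atom or an amine at this place would stand against hydrogen and methoxy, and so whether the step belongs to methoxy in particular or to any group there. They also leave open whether the exchange of chloro and methoxy at the other place would stay as small with hydrogen in place of the methoxy discussed here.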